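From Methoxy to Hydroxy on a Shared Core

The compounds below may be only part of what the source reports. "The series", "measured", "known", "first", "only" and "open" are said of these compounds alone.

Compound 1, `O=C1CSC(c2ccc(Cl)cc2)N1CCN1CCCCC1`, gives 74% in an ADME assay on Vero cells (Chlorocebus sabaeus) for cytotoxicity, read by neutral red uptake, tested at 98 ug/mL; on this read-out lower numbers stand for a stronger effect and higher numbers for a weaker effect at the one concentration tested.
Compound 2, `O=C1CSC(c2ccc(F)cc2)N1CCN1CCCCC1`, gives 87%.
Compound 3, `COc1cccc(C2SCC(=O)N2CCN2CCCCC2)c1`, gives 84%.

All three share one core and differ only in the group on the aromatic ring. Compound 3 stands second highest of the three numbers in this assay, though compound 2 and compound 1 both lie within the usual scatter of it. Among the compounds with values here, the only step measured so far is a number 13 percentage points higher from compound 1 to compound 2 (beyond the scatter), fluoro in place of chloro. Compound 4, `O=C1CSC(c2cccc(O)c2)N1CCN1CCCCC1`, is not yet measured. It differs from compound 3 by hydrogen in place of methyl on an oxygen on an aromatic ring. Within the data shown here, no measured step tests this change: the fluoro-for-chloro step concerns a different group, so it gives no guide here. With nothing to point either way, the expected step of a number 2 percentage points lower from compound 3 to compound 4 (within the scatter) is none beyond the scatter, and compound 4 is estimated at 82%, between 66% and 96%.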

Compound 4, a percentage reported as activity, at one concentration (the size of the read-out at that concentration, not a potency): 100%
Estimate against measurement, compound 4: 18 percentage points below, outside the stated range (above it).
By their numbers in this assay, from the lowest: compounds 1, 3 and 2 (each within the scatter of the next, the first and the last beyond it); then compound 4.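

Hydrogen in place of methyl on an oxygen on an aromatic ring gives a number 16 percentage points higher from compound 3 to compound 4 (beyond the scatter) in this assay and so shows that this small change at this position can weaken the effect on the cells at the one concentration tested. Compound 4 also stands clear of the two halogen-bearing compounds, with a number 13 percentage points higher from compound 2 to compound 4 (beyond the scatter) and a number 26 percentage points higher from compound 1 to compound 4 (beyond the scatter) and so has the weakest effect of the four. Nothing shown explains this difference.

As far as these compounds go, with a single hydroxy compound and a single methoxy compound, it remains open whether the same step would appear with the group elsewhere on the ring or with a different core. From the compounds shown here alone, it also remains open how an amine, a carboxylic acid or a longer ethoxy group in this place would read.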